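The source may hold more compounds than are shown below. What is called first, only, known or untested is meant among the compounds shown, and "the series" means these compounds.

Compound 3, `CN(C)CCN(CCN(C)C)c1ccc(C(=O)N2CCc3ccc(OS(N)(=O)=O)cc3C2)cc1`, gives 15.9% in an assay on HEK293 cells for inhibition of Steryl-sulfatase (Homo sapiens), tested at 1 uM (on this read-out higher numbers stand for a stronger effect at the one concentration tested and lower numbers for a weaker effect), the lowest of the three numbers in hand. Compound 1, `CN(CCCN1CCCCC1)c1ccc(C(=O)N2CCc3ccc(OS(N)(=O)=O)cc3C2)cc1`, gives 40.7% in this assay, and compound 2, `CCN(Cc1ccccn1)c1ccc(C(=O)N2CCc3ccc(OS(N)(=O)=O)cc3C2)cc1`, gives 87.7%. The measured steps are a number 47 percentage points higher from compound 1 to compound 2 (beyond the scatter), a number 24.8 percentage points lower from compound 1 to compound 3 (beyond the scatter) and a number 71.8 percentage points lower from compound 2 to compound 3 (beyond the scatter). Compound 4, `CCN(Cc1cccnc1)c1ccc(C(=O)N2CCc3ccc(OS(N)(=O)=O)cc3C2)cc1`, is not yet measured; it differs from compound 3 by ethyl((pyridin-3-yl)methyl)amino in place of bis(2-(dimethylamino)ethyl)amino on an aromatic carbon. The step from compound 2 to compound 3 bears most directly on this change, since compound 2 carries a group of the same kind as the one that enters, differing only in which carbon of the pyridine ring the methylene attaches to; it was a large fall, and compound 4 should undo most of it. The step from compound 1 to compound 3 shows the same group leaving compound 3 as a gain even toward a less similar replacement. A large rise beyond the scatter is therefore expected, a number 59.1 percentage points higher from compound 3 to compound 4 (beyond the scatter), and compound 4 is estimated at 75%, within 45% to 95%.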

Compound 4, a percentage reported as inhibition, at one concentration (the size of the read-out at that concentration, not a potency): 85.2%
The estimate for compound 4 lay 10.2 percentage points below the measured number; the range from low to high includes it.
By their numbers in this assay, from the lowest: compound 3; then compound 1; then compounds 4 and 2 (each within the scatter of the next).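

The change of attachment on the pyridine ring, pyridin-3-yl in place of pyridin-2-yl, gives a number 2.5 percentage points lower from compound 2 to compound 4 (within the scatter), so this assay does not separate these two attachments. The high number seen with compound 2 is therefore not tied to pyridin-2-yl alone. The ethyl((pyridin-3-yl)methyl)amino group also stands well clear of both amine chains at this position on the aromatic carbon, with a number 69.3 percentage points higher from compound 3 to compound 4 (beyond the scatter) and a number 44.5 percentage points higher from compound 1 to compound 4 (beyond the scatter).

Nothing in hand accounts for these differences. Going by these compounds, whether a pyridin-4-yl ring or a plain phenyl ring with no ring nitrogen would hold the number at this position stays open, as does what the ethyl on the amine nitrogen contributes.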